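Swapping a Chloro for a Methyl on a Shared Core

The source may hold more compounds than are shown below. What is called first, only, known or untested is meant among the compounds shown, and "the series" means these compounds.

Three close relatives of one fused core have been tested in a functional assay on LNCaP cells (Homo sapiens) for cytotoxicity, read by MTT assay, with a stated time of 72 h; a higher number here means a weaker inhibitor, a lower number a stronger inhibitor. The parent, compound 1 `c1ccc2nc3c(cc2c1)Cn1c-3nc2ccccc21`, gives 11300 nM. Compound 2 `Brc1cccc2cc3c(nc12)-c1nc2ccccc2n1C3` carries a bromo on an aromatic carbon and gives 8400 nM. Compound 3 `Clc1cccc2cc3c(nc12)-c1nc2ccccc2n1C3` carries a chloro at the same spot and gives 24000 nM, the highest number of the three; its nearest neighbour is compound 1 and its furthest is compound 2. The step of a 2.1-fold higher number from compound 1 to compound 3 (0.33 log units; beyond the scatter) and the step of a 2.9-fold higher number from compound 2 to compound 3 (0.46 log units; beyond the scatter) both show the chloro giving a weaker inhibitor, while a 1.3-fold lower number from compound 1 to compound 2 (0.13 log units; within the scatter) shows the bromo making no difference beyond the scatter.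

Compound 4 `Cc1cccc2cc3c(nc12)-c1nc2ccccc2n1C3` is the next relative. Compared with compound 3, the change is methyl in place of chloro on an aromatic carbon. Going by the values given here, no measured compound carries a methyl here, so the only guide is that a hydrogen and a bromo at this position both gave lower numbers than the chloro, and the gaps were modest. A methyl is expected to land somewhere in that neighbourhood, so the expected step is a 2.0-fold lower number from compound 3 to compound 4 (0.30 log units; within the scatter), a modest move to a lower number. For compound 4 in this assay the estimated value is 12000 nM, with a range from 5000 nM to 30000 nM.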

Compound 4, half-maximal inhibitory concentration: 23800 nM
Compound 4: the middle estimate sits 2.0-fold (0.30 log units) below what was measured, within the range that was stated.
By their numbers in this assay, from the lowest: compounds 2 and 1 (each within the scatter of the next); then compounds 4 and 3 (each within the scatter of the next).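

In this assay, methyl in place of chloro gives a 1.0-fold lower number from compound 3 to compound 4 (0.00 log units; within the scatter) at this position, so the chloro result no longer stands alone: two different groups now give values that cannot be told apart. Compound 4 also shares the gap that compound 3 showed from the other two compounds, with a 2.1-fold higher number from compound 1 to compound 4 (0.32 log units; beyond the scatter) and a 2.8-fold higher number from compound 2 to compound 4 (0.45 log units; beyond the scatter) as modest steps, both beyond the scatter, so a group here can leave a weaker inhibitor than the unsubstituted parent, although compound 2 goes against any rule that every group does so. Nothing measured for these compounds explains why methyl and chloro match while bromo stands apart from them.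

The compounds shown leave open how a group of a different kind, such as an amine, a methoxy group or a carboxylic acid, would behave at this position, and whether any such group could give a clearly lower number than the parent. They also leave open whether the match between methyl and chloro would hold at another place on the shared core.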